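From 2-bromophenyl to 3-hydroxyphenyl

The source may report more compounds than this note shows. Statements on the series, on what has been measured and on what is new or still open speak of the compounds shown alone.

Compound 1 `COc1cccc(/C=C2\CCC/C(=C\c3ccccc3Br)C2=O)c1OC`: 9700 nM
Compound 2 `COc1cccc(/C=C2\CCC/C(=C\c3ccc(Br)cc3)C2=O)c1OC`: 13800 nM

Going by the values given here, in a functional assay on MCF7 cells (Homo sapiens) for cytotoxicity, read by MTT assay, with a stated time of 72 h (a lower number here means a stronger inhibitor, a higher number a weaker inhibitor), compound 1 gives 9700 nM and compound 2 gives 13800 nM, so compound 1 stands level with its only measured neighbour. Compound 3 `COc1cccc(/C=C2\CCC/C(=C\c3cccc(O)c3)C2=O)c1OC` has not yet been measured. It differs from compound 1 as follows: 3-hydroxyphenyl in place of 2-bromophenyl on a double-bonded chain carbon bound to a double-bonded ring carbon. In words, 3-hydroxyphenyl stands in place of 2-bromophenyl on a double-bonded chain carbon bound to a double-bonded ring carbon. Among the compounds with values here, one measured step bears on this place, and it shows a 1.4-fold higher number from compound 1 to compound 2 (0.15 log units; within the scatter). Within the data shown here, that step only exchanges one bromophenyl for another, and no measured compound carries a 3-hydroxyphenyl, so the guidance is thin. No shift beyond the scatter is therefore expected. The expected change is a 1.1-fold lower number from compound 1 to compound 3 (0.03 log units; within the scatter). For compound 3 the estimated value is 9000 nM, with an expected range of 3000 nM to 27000 nM.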

Compound 3, half-maximal inhibitory concentration: 8800 nM
Beside the measured number, compound 3's estimate is 1.0-fold (0.01 log units) above it; low and high end bracket the measured number.
By their numbers in this assay, from the lowest: compounds 3, 1 and 2 (each within the scatter of the next).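

In this assay, the earlier pair had only exchanged one bromophenyl for another, whereas compound 3 replaces the bromine-bearing ring with 3-hydroxyphenyl at this place, giving a 1.1-fold lower number from compound 1 to compound 3 (0.04 log units; within the scatter) and a 1.6-fold lower number from compound 2 to compound 3 (0.20 log units; within the scatter). Thus, a ring without bromine, and with the hydrogen-bond donor and acceptor counted for 3-hydroxyphenyl, leaves the number level with those of both bromophenyl compounds. Nothing available explains this lack of separation.

From the compounds shown here alone, all three compounds carry a phenyl ring with a single substituent at this place, so it remains open whether an amine, a carboxylic acid or a longer chain there would move the number beyond the scatter. The rest of the core is the same in all three, so they show nothing about changes elsewhere.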